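The compounds below may be only part of what the source reports. "The series", "measured", "known", "first", "only" and "open" are said of these compounds alone.

Compound 1 `O=C(/C=C/c1ccccc1)OCC1COCCOCCOCCOCCOCCO1`: in a functional assay on HeLa cells (Homo sapiens) for inhibition, read by sulforhodamine B assay, with a stated time of 48 h (on this read-out lower numbers stand for stronger inhibition of growth and higher numbers for weaker inhibition of growth), compound 1 gives 48000 nM.
Compound 2 `O=C(CCCCCc1ccccc1)OCC1COCCOCCOCCOCCOCCO1`: in this assay compound 2 gives 79000 nM.
Compound 3 `O=C(CCCc1cc2ccccc2[nH]1)OCC1COCCOCCOCCOCCOCCO1`: in this assay compound 3 reaches only > 100000 nM, which is a limit of the assay and not a number.

Among the two numbers shown, compound 1 has the lowest, with compound 2 nearest to it. Compound 4 `O=C(CCCCc1ccccc1)OCC1COCCOCCOCCOCCOCCO1` differs from compound 1 in one place: 4-phenylbutyl in place of 2-phenylethenyl on a carbonyl carbon. The measured step that bears on this change is a 1.6-fold higher number from compound 1 to compound 2 (0.22 log units; within the scatter), where 5-phenylpentyl likewise replaced 2-phenylethenyl on a carbonyl carbon and the number stayed within the scatter. A 4-phenylbutyl group is expected to give much the same outcome, so in this assay a step of a 1.3-fold higher number from compound 1 to compound 4 (0.10 log units; within the scatter) is expected, not beyond the scatter. Compound 4 is therefore estimated at 60000 nM, with a range from 30000 nM to 120000 nM.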

Compound 4, concentration for 50% growth inhibition: 52000 nM
Estimate against measurement, compound 4: 1.2-fold (0.06 log units) above; measured number inside the range.
By their numbers in this assay, from the lowest: compounds 1, 4 and 2 (each within the scatter of the next). At a limit, above all of these: compound 3.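

Replacing 2-phenylethenyl with 4-phenylbutyl on the carbonyl carbon removes the double bond outside the aromatic ring, yet in this assay there is a 1.1-fold higher number from compound 1 to compound 4 (0.03 log units; within the scatter). The 5-phenylpentyl and 4-phenylbutyl chains also show no readable difference, with a 1.5-fold lower number from compound 2 to compound 4 (0.18 log units; within the scatter). The remaining step is an at least 1.9-fold lower number from compound 3 to compound 4 (0.28 log units; that floor lies within the scatter) and cannot be read to an exact size. Compound 3 stands at a limit of the assay: the limit of > 100000 nM in this assay, at which 1 of the 4 values shown sits.

As far as these compounds go, it remains open whether a shorter chain, or an amine or carboxylic acid on the chain, would move the number beyond the scatter.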